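This account rests on a few compounds, and the source may have more. Where it says the series, first, only, none or still open, it means among the compounds named here.

Working notes on the series.

Compound 1 `CC1=C(C(=O)CC(C)C)C(c2ccco2)NC(=O)N1` gives, in an assay on membranes from HeLa cells for displacement of a labelled ligand from adenosine receptor A3 (Homo sapiens), read by scintillation counting, with a stated time of 180 min, tested at 1 uM (a higher number here means more inhibition at the concentration tested (going by the name of the read-out), a lower number less inhibition), 31%. Compound 2 `CCN(CC)C(=O)C1=C(C)NC(=O)NC1c1ccco1` gives 19% in this assay, and compound 3 `CC1=C(C(=O)SC(C)C)C(c2ccco2)NC(=O)N1` gives 1% in this assay. Compound 3 thus stands lowest of the three numbers: the steps of a number 30 percentage points lower from compound 1 to compound 3 (beyond the scatter) and a number 18 percentage points lower from compound 2 to compound 3 (beyond the scatter) both fall beyond the scatter, and a number 12 percentage points lower from compound 1 to compound 2 (beyond the scatter) as well, so compound 3 sits furthest from compound 1 and nearest to compound 2.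

Compound 4 `CC1=C(C(=O)OCC2CCC2)C(c2ccco2)NC(=O)N1` has not yet been measured in this assay. The change from compound 3 is cyclobutylmethoxy in place of isopropylsulfanyl on a carbonyl carbon. The two steps that touch the same place, a number 30 percentage points lower from compound 1 to compound 3 (beyond the scatter) and a number 18 percentage points lower from compound 2 to compound 3 (beyond the scatter), both show that the isopropylsulfanyl group carries the lowest number in the set, and that either other group on that carbonyl carbon gives a higher number. Among the compounds with values here, no measured compound carries cyclobutylmethoxy, so the size of the step is open; the expectation is a rise, estimated as a number 19 percentage points higher from compound 3 to compound 4 (beyond the scatter), landing between the values of compound 3 and compound 1. Compound 4 is therefore expected to give about 20% in this assay, within 5% to 40%.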

Compound 4, a percentage reported as inhibition, at one concentration (the size of the read-out at that concentration, not a potency): 1%
Compound 4: the middle estimate sits 19 percentage points above what was measured; measured number outside the range, below it.
By their numbers in this assay, from the lowest: compounds 3 and 4 (each within the scatter of the next); then compound 2; then compound 1.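

In this assay, replacing isopropylsulfanyl with cyclobutylmethoxy on the carbonyl carbon gives no change at the digits printed from compound 3 to compound 4 (within the scatter) even though the entering group is larger and carries a four-membered ring, so the low number is not confined to the sulfur-linked group. Compound 4 also shows a number 18 percentage points lower from compound 2 to compound 4 (beyond the scatter) and a number 30 percentage points lower from compound 1 to compound 4 (beyond the scatter) in this comparison, so among these four compounds alone, the oxygen-linked and sulfur-linked groups both give lower numbers than diethylamino and isobutyl, with none going against this. No evidence on hand bears on the reason for this result.

On these data alone, whether a methoxy group, a longer chain on the oxygen or a carboxylic acid at this carbonyl carbon would also stay this low remains open. The compounds shown also leave open whether a primary amine or a shorter amide group would match or exceed the number of compound 2.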